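Methyl to Chloro Swap in a Hydrolase Inhibitor Pair

The source may report more compounds than this note shows. Statements on the series, on what has been measured and on what is new or still open speak of the compounds shown alone.

Measured compounds in an assay on isolated protein for inhibition of leukotriene A-4 hydrolase (Homo sapiens); on this read-out lower numbers stand for stronger inhibition and higher numbers for weaker inhibition:
compound 1 `Cc1ccc(-c2csc(=N)n2CC(=O)N2CCN(c3ccccc3)CC2)cc1` gives 4290 nM
compound 2 `CC(=O)N1CCN(C(=O)Cn2c(-c3ccc(C)cc3)csc2=N)CC1` gives 1640 nM

Among the measured compounds shown here, compound 2 stands at the lowest of the two numbers in this assay; the only step between them, a 2.6-fold lower number from compound 1 to compound 2 (0.42 log units; beyond the scatter), concerns the amine nitrogen in the ring and is beyond the scatter. Compound 3 `CC(=O)N1CCN(C(=O)Cn2c(-c3ccc(Cl)cc3)csc2=N)CC1` differs from compound 2 in chloro in place of methyl on an aromatic carbon, that is, 4-methylphenyl becomes 4-chlorophenyl. For the measured compounds named here, neither measured step touches this ring: the one step known, a 2.6-fold lower number from compound 1 to compound 2 (0.42 log units; beyond the scatter), alters a different part of the shared core, and no pair shows what a chloro in place of a methyl on this aromatic carbon does in this assay. In the absence of any bearing step, the change is expected to stay within the scatter, in no set direction, and compound 3 is therefore estimated at 1500 nM, between 500 nM and 4500 nM. The step from compound 2 to compound 3 is thus expected to be a 1.1-fold lower number from compound 2 to compound 3 (0.04 log units; within the scatter).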

Compound 3, inhibition constant: 607 nM
The estimate for compound 3 lay 2.5-fold (0.39 log units) above the measured number; the measured number falls inside the stated range.
By their numbers in this assay, from the lowest: compound 3; then compound 2; then compound 1.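

The position on the aromatic ring, para to a large group, turns out to matter in this series: in this assay, chloro in place of methyl gives a change beyond the scatter (a 2.7-fold lower number from compound 2 to compound 3 (0.43 log units; beyond the scatter)). The earlier step (a 2.6-fold lower number from compound 1 to compound 2 (0.42 log units; beyond the scatter)) concerned only the group on the amine nitrogen in the ring, so it said nothing about this carbon; now a second part of the shared core is seen to respond, and to a swap of one heavy atom for one heavy atom, with no hydrogen-bond donor or acceptor entering or leaving. No supporting measurement is available to explain the difference between methyl and chloro here.

The compounds shown leave open whether other groups on this carbon, such as fluoro, methoxy, an amine or a carboxylic acid, would move the number in the same direction as chloro or in the opposite one. They also leave open whether chloro would give a similar step with phenyl rather than acetyl on the amine nitrogen in the ring, as in compound 1.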